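Methylating a phenol on a lactone-bearing styryl series

The source may hold more compounds than are shown below. What is called first, only, known or untested is meant among the compounds shown, and "the series" means these compounds.

The measured compounds:
compound 1 `COc1ccc(/C=C/C2(C)C=CC(=O)O2)c(OC)c1OC`: 110000 nM
compound 2 `COc1c(O)ccc(/C=C/C2(C)C=CC(=O)O2)c1OC`: 45300 nM
compound 3 `CC1(/C=C/c2cccc(O)c2)C=CC(=O)O1`: 124000 nM

In a functional assay on MCF7 cells (Homo sapiens) for inhibition, read by sulforhodamine B assay, with a stated time of 48 h (a higher number here means a weaker inhibitor of growth, a lower number a stronger inhibitor of growth), compound 2 gives 45300 nM, and compound 1, which differs from it by methyl in place of hydrogen on an oxygen on an aromatic ring, gives 110000 nM. That single change produced a 2.4-fold higher number from compound 2 to compound 1 (0.39 log units; beyond the scatter). Compound 3 gives 124000 nM in this assay, a number within the scatter of compound 1 and beyond the scatter of compound 2. How the core of compound 3 differs from that of compound 2 is not broken down here.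

Compound 4 `COc1cccc(/C=C/C2(C)C=CC(=O)O2)c1` has not been measured. Going by the values given here, it differs from compound 3 by methyl in place of hydrogen on an oxygen on an aromatic ring, the same change, at the same kind of place, as the one that turned compound 2 into compound 1. Resting on that single earlier step, the expected step in this assay is a 2.0-fold higher number from compound 3 to compound 4 (0.30 log units; within the scatter), of a size like the one observed from compound 2 to compound 1, with wider bounds because only one such pair is known. Compound 4 is therefore estimated at 250000 nM, expected between 110000 nM and 560000 nM.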

Compound 4, concentration for total growth inhibition: 25300 nM
Estimate against measurement, compound 4: 9.9-fold (0.99 log units) above; measured number below the stated range.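

On the core of compound 3, the change from hydroxy to methoxy in this assay gave a 4.9-fold lower number from compound 3 to compound 4 (0.69 log units; beyond the scatter), so methylation went with a stronger growth-inhibition reading here and a weaker one on the core of compound 2. The same change therefore did not carry across these two cores in either direction or size: the same change on two cores in this assay, a 2.4-fold higher number (0.39 log units; beyond the scatter) from compound 2 to compound 1 and a 4.9-fold lower number (0.69 log units; beyond the scatter) from compound 3 to compound 4, 12-fold (1.08 log units) apart, beyond the scatter of two such steps. Going by these compounds alone, this shows that a step measured on one core of this series cannot safely be transferred to the other, but with only one pair on each core it does not show which difference between the cores is responsible, nor which direction a further core would follow.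

The compounds shown leave open whether a longer chain, such as ethyl, on the same oxygen would follow the step to compound 1 or the step to compound 4. They also leave open how an amine in place of the hydroxy group would read on either core.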